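Removing Two Fluorines from the Aryl Group on the Core

The source may hold more compounds than are shown below. What is called first, only, known or untested is meant among the compounds shown, and "the series" means these compounds.

Measured so far:
compound 1, `Cc1c(Br)sc(N)c1C(=O)c1ccc(Cl)cc1`: 1%
compound 2, `CC(C)(C)Cc1c(-c2cc(F)ccc2F)sc(N)c1C(=O)c1ccc(Cl)cc1`: 3%

Both numbers come from an assay on CHO cells for displacement of a labelled ligand from adenosine receptor A1 (Homo sapiens), read by scintillation counting, tested at 10 uM; a lower number here means less inhibition, a higher number more inhibition at the concentration tested (going by the name of the read-out). Compound 2 and compound 1 lie within the usual scatter of each other, so neither stands apart; both show almost no inhibition. Compound 3, `CC(C)(C)Cc1c(-c2ccccc2)sc(N)c1C(=O)c1ccc(Cl)cc1`, is not yet measured. It differs from compound 2 in one place: phenyl in place of 2,5-difluorophenyl on an aromatic carbon. Going by the values given here, no measured pair shows what such a change does, and both known values sit near zero, so no step beyond the scatter in either direction is expected in this assay. The step of a number 1 percentage points lower from compound 2 to compound 3 (within the scatter) is expected to be small. Compound 3 is estimated at 2%, with a range from 0% to 12%.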

Compound 3, a percentage reported as inhibition, at one concentration (the size of the read-out at that concentration, not a potency): 1%
Beside the measured number, compound 3's estimate is 1 percentage points above it; measured number inside the range.
By their numbers in this assay, from the lowest: compounds 1, 3 and 2 (each within the scatter of the next).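

Putting phenyl in place of 2,5-difluorophenyl on this aromatic carbon, next to the ring sulfur, gives a number 2 percentage points lower from compound 2 to compound 3 (within the scatter) in this assay. This first measured pair at the position shows that removing the two fluorines leaves no mark that can be told from the scatter, though with both compounds near zero it cannot show what they would do in a compound with clear inhibition. Nothing available bears on the reason for this result. Going by these compounds, whether an amine or a carboxylic acid on the phenyl ring, or a longer chain in place of neopentyl, would give clear inhibition remains open.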